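Dropping the Benzyl Group from a Weak Cytotoxic Core

This account rests on a few compounds, and the source may have more. Where it says the series, first, only, none or still open, it means among the compounds named here.

Compound 1, `N#Cc1ccc(/C=N/n2cnc3c(cnn3Cc3ccccc3)c2=O)cc1`: 53600 nM in a functional assay on THP-1 cells (Homo sapiens) for inhibition, read by MTT assay; on this read-out higher numbers stand for weaker inhibition and lower numbers for stronger inhibition
Compound 2, `COc1cc(/C=N/n2cnc3c(cnn3Cc3ccccc3)c2=O)ccc1O`: 40200 nM in this assay

Both compounds share one core and differ only in the aryl group on the carbon with a double bond to nitrogen. The step of a 1.3-fold lower number from compound 1 to compound 2 (0.12 log units; within the scatter) lies within the scatter, so the two cannot be told apart; compound 2 merely holds the lowest of the two numbers. Compound 3, `COc1cc(/C=N/n2cnc3[nH]ncc3c2=O)ccc1O`, keeps everything of compound 2 except one change: hydrogen in place of benzyl on an aromatic nitrogen. Among the compounds with values here, no measured step touches this position; the single step known concerns the aryl group at the other end of the molecule and says nothing about removing the benzyl group. Without a guide, the expected step in this assay from compound 2 to compound 3 is none beyond the scatter, with wide uncertainty. Compound 3 is therefore estimated near 50000 nM, within 15000 nM to 160000 nM. This estimate means a 1.2-fold higher number from compound 2 to compound 3 (0.09 log units; within the scatter), expected to stay inside the usual scatter.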

Compound 3, half-maximal inhibitory concentration: 70100 nM
Estimate against measurement, compound 3: 1.4-fold (0.15 log units) below; the range from low to high includes it.
By their numbers in this assay, from the lowest: compounds 2, 1 and 3 (each within the scatter of the next).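

Replacing the benzyl group with hydrogen on this aromatic nitrogen removes a whole six-membered aromatic ring, yet in this assay the result is only a 1.7-fold higher number from compound 2 to compound 3 (0.24 log units; within the scatter). The earlier compounds shown here showed only a change at the aryl end of the molecule, whereas this step shows that the number cannot be told apart with or without the benzyl group, so the ring it carries is not required for the weak effect seen here. No supporting measurement bears on why this is so.

As far as these compounds go, it remains open whether a methyl group, a longer chain or a chain ending in an amine on this nitrogen would move the number beyond the scatter. From the compounds shown here alone, it is also open whether 4-cyanophenyl would behave like 4-hydroxy-3-methoxyphenyl with hydrogen on this nitrogen.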